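Cyclopropyl for Methyl, Repeated on a Second Core

A few compounds are considered here, and "the series" means these few. Any claim that something is new, unique, unknown or untested is made for them only; others in the source may bear on it.

Of the compounds shown here, three have so far been measured in an assay for inhibition of high affinity nerve growth factor receptor (Homo sapiens), read by HTRF, with a stated time of 30 min, in the presence of a further agent that is not named here; a lower number here means a stronger inhibitor, a higher number a weaker inhibitor. Compound 1 `Cc1cc(Nc2nc(NCc3ccc(F)cc3)nc3ccccc23)n[nH]1` gives 20 nM. In this assay compound 2 `Fc1ccc(CNc2nc(Nc3cc(C4CC4)[nH]n3)c3ccccc3n2)cc1` gives 40 nM. Compound 3 `Cc1ccc2nc(NCc3ccc(F)cc3F)nc(Nc3cc(C)[nH]n3)c2c1` is built on a different core, and in this assay compound 3 gives 110 nM, the highest of the three numbers, standing beyond the scatter from both compound 1 and compound 2. How the core of compound 3 differs from the core of compound 1 is not broken down here.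

The change from compound 1 to compound 2 is cyclopropyl in place of methyl on an aromatic carbon, and the resulting step is a 2.0-fold higher number from compound 1 to compound 2 (0.30 log units; within the scatter). Compound 4 `Cc1ccc2nc(NCc3ccc(F)cc3F)nc(Nc3cc(C4CC4)[nH]n3)c2c1` has not yet been measured. It differs from compound 3 by cyclopropyl in place of methyl on an aromatic carbon, the same change at the same place, so the pair compound 3 and compound 4 repeats on the second core what compound 1 and compound 2 show on the first.

An expectation for compound 4 rests on that single precedent. Because the earlier pair gave a 2.0-fold higher number from compound 1 to compound 2 (0.30 log units; within the scatter), the step from compound 3 to compound 4 in this assay is expected to be a 1.8-fold higher number from compound 3 to compound 4 (0.26 log units; within the scatter), a shift of about the same size and direction. As far as these compounds go, whether the second core responds in the same way is untested, so the range is kept wide. Compound 4 is therefore estimated at 200 nM, with a likely span from 90 nM to 450 nM.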

Compound 4, half-maximal inhibitory concentration: 57 nM
For compound 4 the middle estimate is 3.5-fold (0.55 log units) above the measured one; the whole stated range lies above it.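

In this assay the change from 5-methyl-1H-pyrazol-3-yl to 5-cyclopropyl-1H-pyrazol-3-yl gives a 1.9-fold lower number from compound 3 to compound 4 (0.29 log units; within the scatter), and the step seen on the first core does not carry over to the second in direction or size: the same change on two cores in this assay, a 2.0-fold higher number (0.30 log units; within the scatter) from compound 1 to compound 2 and a 1.9-fold lower number (0.29 log units; within the scatter) from compound 3 to compound 4, 3.9-fold (0.59 log units) apart, beyond the scatter of two such steps. What the two pairs show together is that, in this small set, the step measured for this change on one core gave a poor guide to the step on the other, even though neither step alone lies beyond the scatter. They do not show that cyclopropyl makes compounds stronger or weaker inhibitors on either core, and since the second pair differs from the first in more than one place, they do not show which feature of the core of compound 3 goes with the different outcome.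

The compounds shown leave open whether the gap between the two steps would hold up with further pairs, including pairs that differ from the core of compound 1 in only one place. They also leave open how an ethyl, an isopropyl or a trifluoromethyl group in place of the methyl would behave on each of the two cores.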